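Squaraine series: branching of the nitrogen alkyl group

A few compounds are considered here, and "the series" means these few. Any claim that something is new, unique, unknown or untested is made for them only; others in the source may bear on it.

Measured compounds:
Compound 1 `CCC(CC)/N=c1\c(O)c(O)\c1=N/Cc1ccc(C#N)cc1` — 1300 nM
Compound 2 `Cc1cc(Br)cc(C)c1C/N=c1\c(O)c(O)\c1=N/C(C)(C)C` — 290 nM
Compound 3 `CCC(C)(C)/N=c1\c(O)c(O)\c1=N/Cc1cc(F)cc(F)c1` — 750 nM

All three were run in a functional assay for inhibition, with Rattus norvegicus as the target; a lower number here means a stronger inhibitor, a higher number a weaker inhibitor. Compound 1 gives the highest number of the three at 1300 nM. Compound 3 gives 750 nM, and this gap to compound 1 lies within the scatter, so no order between these two is claimed. Compound 2 gives 290 nM, a gap to compound 1 beyond the scatter; compound 2 differs from compound 1 at both ends of the shared core, so no single structural cause is assigned.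

The next compound, compound 4 `CC(C)(C)/N=c1\c(O)c(O)\c1=N/Cc1ccc(C#N)cc1`, keeps the nitrile-bearing benzyl side of compound 1 and changes only the alkyl group on the other nitrogen: tert-butyl in place of pentan-3-yl on a double-bonded nitrogen

Among the measured compounds shown here, no pair among the measured compounds isolates this change. The expectation rests on compound 2, whose tert-butyl group accompanies the lowest number at 290 nM. A modest step toward a lower number, a 1.6-fold lower number from compound 1 to compound 4 (0.21 log units; within the scatter), is expected, though a result within the scatter of compound 1 would not surprise. Compound 4 is estimated at 800 nM with a range from 300 nM to 2000 nM in this assay.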

Compound 4, half-maximal inhibitory concentration: 270 nM
Estimate against measurement, compound 4: 3.0-fold (0.47 log units) above, outside the stated range (below it).
By their numbers in this assay, from the lowest: compounds 4 and 2 (each within the scatter of the next); then compounds 3 and 1 (each within the scatter of the next).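

Among the compounds shown here, with the nitrile-bearing benzyl side held fixed, tert-butyl in place of pentan-3-yl on a double-bonded nitrogen gives in this assay a 4.8-fold lower number from compound 1 to compound 4 (0.68 log units; beyond the scatter), the first step to isolate this position, and it lies beyond the scatter. Neither group carries a ring, a hydrogen-bond donor or acceptor, or a net charge, so the number at this position responds to a change between two plain alkyl groups. Nothing at hand explains the step.

Open, on these data alone, is whether an isopropyl group, a cyclopropyl group or a straight pentyl chain on this nitrogen would track with tert-butyl or with pentan-3-yl. Also open, as far as these compounds go, is whether the same exchange gives a step of similar size when the nitrile-bearing benzyl side is replaced by the difluorobenzyl side of compound 3.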